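The source may hold more compounds than are shown below. What is called first, only, known or untested is meant among the compounds shown, and "the series" means these compounds.

Measured so far:
compound 1 `C#Cc1cccc(NC(=O)CCc2cccc3c2B(O)OC3)c1` — > 100000 nM
compound 2 `COc1ccccc1NC(=O)CCc1cccc2c1B(O)OC2` — 1600 nM

The two measured compounds share a core and differ at the amide-bearing ring. In an ADME assay on WI-38 cells (Homo sapiens) for cytotoxicity, read by MTT assay, with a stated time of 72 h (on this read-out higher numbers stand for weaker inhibition and lower numbers for stronger inhibition), compound 1 gives > 100000 nM, which is a limit of the assay and not a number. Compound 2 in this assay gives 1600 nM. For the measured compounds named here, no step between these two is given, so only the two values themselves can be stated: one a limit (the limit of > 100000 nM in this assay, at which 1 of the 2 values shown sits), the other a number.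

Compound 3 `O=C(CCc1cccc2c1B(O)OC2)Nc1cccc(-c2ccc(C(F)(F)F)cc2)c1` is not yet measured. It differs from compound 1 in one place: 4-(trifluoromethyl)phenyl in place of ethynyl on an aromatic carbon.

With only a limit for compound 1, the size of the step to compound 3 in this assay cannot be anchored on a measured value; the change is large in what it adds, and the expectation is a step of an at least 2.5-fold lower number from compound 1 to compound 3 (0.39 log units; beyond the scatter) toward a measurable number rather than one that stays at the limit. Compound 3 is therefore expected to give about 40000 nM, with a range from 8000 nM to 200000 nM, while a limit remains a real possibility.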

Compound 3, half-maximal inhibitory concentration: 26000 nM
The estimate for compound 3 lay 1.5-fold (0.19 log units) above the measured number, within the range that was stated.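

In this assay, replacing ethynyl with 4-(trifluoromethyl)phenyl on this aromatic carbon gives an at least 3.8-fold lower number from compound 1 to compound 3 (0.58 log units; beyond the scatter), so a change at this position can bring the read-out to a measurable number. The entering group adds a six-membered aromatic ring of carbon only but no hydrogen-bond donors or acceptors, which shows that the number can move without any change in those counts. Compound 1 stands at a limit of the assay and not at a number, so the step has a lower bound but no fixed size: the limit of > 100000 nM in this assay, at which 1 of the 3 values shown sits.

The compounds shown do not tell whether the step belongs to the new aromatic ring itself or to the trifluoromethyl group it carries, a question that a plain phenyl group at the same position would address. They also leave open how an amine or a carboxylic acid on that ring would read in this assay, and whether 4-(trifluoromethyl)phenyl would give a step of similar size on a different aromatic carbon of the same ring.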